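The source may hold more compounds than are shown below. What is called first, only, known or untested is meant among the compounds shown, and "the series" means these compounds.

In a functional assay on MDA-MB-231 cells (Homo sapiens) for antiproliferative activity, with a stated time of 5 days (a lower number here means a stronger inhibitor, a higher number a weaker inhibitor), compound 1 `COc1ccc(-n2nc(-c3ccc4ccccc4c3)nc2N2C(=O)COC23C=CC(=O)C=C3)cc1` gives 60 nM. Compound 2 `O=C1C=CC2(C=C1)OCC(=O)N2c1nc(-c2ccc3ncccc3c2)nn1-c1ccccc1` gives 50 nM, and compound 3 `CC1OC2(C=CC(=O)C=C2)N(c2nc(-c3ccc4ccccc4c3)nn2-c2ccccc2)C1=O` gives 70 nM. All three numbers lie within the scatter of one another, so compound 1 stands level with both of the others.

Compound 4 `Cc1ccc(-n2nc(-c3ccc4ccccc4c3)nc2N2C(=O)COC23C=CC(=O)C=C3)cc1` departs from compound 1 in one place, with methyl in place of methoxy on an aromatic carbon, para to a large group (methyl in place of methoxy on an aromatic carbon). The 4-methoxyphenyl thus becomes 4-methylphenyl, and the rest of the structure stays the same. Within the data shown here, no two measured compounds differ in one place only, so the data offer no direct measure of this change. Compound 3 carries no methoxy and gives 70 nM, which suggests that the group is not required for a number of this size. No step beyond the scatter is therefore expected in this assay, in either direction. The expected change is no change at the digits printed from compound 1 to compound 4 (within the scatter), which is estimated to stay within the scatter. For compound 4 the estimated value is 60 nM, with an expected range from 30 nM to 120 nM.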

Compound 4, half-maximal inhibitory concentration: 30 nM
Compound 4: middle estimate off by 2.0-fold (0.30 log units), on the high side; the range from low to high includes it.
By their numbers in this assay, from the lowest: compounds 4, 2, 1 and 3 (each within the scatter of the next, the first and the last beyond it).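

In this assay, among these compounds, the step of a 2.0-fold lower number from compound 1 to compound 4 (0.30 log units; within the scatter) is the first direct reading of a change at this place on the aromatic ring, para to a large group. It shows that methyl can stand in place of methoxy with the difference staying inside the usual scatter, so the 4-methylphenyl compound reads level with the 4-methoxyphenyl compound. On this core, then, neither the oxygen nor the hydrogen-bond acceptor that leaves with the methoxy is needed to keep a number of this size in this assay.

On these data alone, whether the same holds for a carboxylic acid, an amine or a longer chain such as butoxy at this place remains open, as a single step between two small groups cannot say how far the tolerance extends. Nothing shown bears on the reason for this reading.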